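The source may hold more compounds than are shown below. What is called first, only, known or untested is meant among the compounds shown, and "the series" means these compounds.

Measured so far:
- compound 1, `C[C@@H](O)CNc1cc(Oc2ccc(NC(=O)Nc3cccc(C(F)(F)F)c3)cc2)ncn1`: 63 nM in an assay on isolated protein for inhibition of serine/threonine-protein kinase TNNI3K (Homo sapiens); on this read-out lower numbers stand for stronger inhibition and higher numbers for weaker inhibition
- compound 2, `CC(C)CNc1cc(Oc2ccc(NC(=O)Nc3cccc(C(F)(F)F)c3)cc2)ncn1`: 50 nM
- compound 3, `CNc1cc(Oc2ccc(NC(=O)Nc3cccc(C(F)(F)F)c3)cc2C)ncn1`: <= 10 nM

The value given for compound 3 is a limit of the assay rather than a number, and one of the three results shown sits at that limit (the limit of <= 10 nM in this assay, at which 1 of the 3 values shown sits). Among the two outright numbers, compound 2 and compound 1 differ only by a 1.3-fold lower number from compound 1 to compound 2 (0.10 log units; within the scatter), a step that lies within the scatter, so the two cannot be told apart; this step swaps isopropyl for 1-hydroxyethyl on a saturated chain carbon bound to a nitrogen on an aromatic ring.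

Compound 4, `CC(=O)Nc1cc(Oc2ccc(NC(=O)Nc3cccc(C(F)(F)F)c3)cc2)ncn1`, is not yet measured. It differs from compound 2 in one place: acetyl in place of isobutyl on a nitrogen on an aromatic ring. Within the data shown here, no measured step covers a change of this kind, since the only step available exchanges one saturated branch for another and stays within the scatter, and compound 3 carries a further methyl on another ring, so its limit does not bear on this change alone. For compound 4 in this assay a modestly higher number is expected, that is a step of a 3.0-fold higher number from compound 2 to compound 4 (0.48 log units; beyond the scatter), giving an estimated 150 nM with a range from 40 nM to 600 nM.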

Compound 4, half-maximal inhibitory concentration: 20 nM
For compound 4 the middle estimate is 7.5-fold (0.88 log units) above the measured one; measured number below the stated range.
By their numbers in this assay, from the lowest: compound 4; then compounds 2 and 1 (each within the scatter of the next). At a limit, below all of these: compound 3.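

Until now, the only change shown on this nitrogen swapped one side chain for another and stayed within the scatter, but in this assay replacing isobutyl with acetyl gives a step beyond it: a 2.5-fold lower number from compound 2 to compound 4 (0.40 log units; beyond the scatter). The comparison with the 2-hydroxypropyl chain points the same way: a 3.2-fold lower number from compound 1 to compound 4 (0.50 log units; beyond the scatter). The nitrogen on the aromatic ring therefore accepts an acyl group as well as the saturated chains, and here the number falls rather than rises, although a single acetyl compound cannot separate the effect of the carbonyl from that of the change in chain size.

Still open, on these data alone, is whether a longer acyl chain such as propionyl, a benzoyl group or a free amine on this nitrogen would lower the number further, and whether acetyl would also be tolerated with the further methyl on the other ring that compound 3 carries. Any further gain may be hard to size in this assay, since its readings stop at a limit: the limit of <= 10 nM in this assay, at which 1 of the 4 values shown sits.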